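Compound 3: 2,4,6-trimethoxyphenyl in place of 4-methoxyphenyl

The source may hold more compounds than are shown below. What is called first, only, known or untested is meant among the compounds shown, and "the series" means these compounds.

Measured in a functional assay on NCI-H460 cells (Homo sapiens) for cytotoxicity, read by MTT assay, with a stated time of 48 h; on this read-out higher numbers stand for weaker inhibition and lower numbers for stronger inhibition:
- compound 1 `COc1ccc(/C=C/C(=O)/C=C/c2cc3ccccc3nc2Cl)cc1`: > 10000 nM
- compound 2 `COc1ccc(/C=C/C(=O)/C=C/c2cc3ccccc3nc2Oc2ccc(Br)cc2)cc1`: > 10000 nM

Both entries are limits of the assay, not numbers. Compound 2 stands at the limit of > 10000 nM in this assay, at which 2 of the 2 values shown sit.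

Compound 3 `COc1cc(OC)c(/C=C/C(=O)/C=C/c2cc3ccccc3nc2Oc2ccc(Br)cc2)c(OC)c1` differs from compound 2 in one place: 2,4,6-trimethoxyphenyl in place of 4-methoxyphenyl on a double-bonded chain carbon bound to a double-bonded chain carbon. Going by the values given here, the only measured step, a step that the two limits leave unreadable from compound 1 to compound 2, replaces a different group and has no readable size, so it gives no size to carry over to this change.

The limit of compound 2 at > 10000 nM leaves only stronger inhibition open to a readable result. A modest move in that direction is expected in this assay, with a real chance of another limit. The estimated step is an at least 1.6-fold lower number from compound 2 to compound 3 (0.22 log units; that floor lies within the scatter). Compound 3 is expected at 6000 nM, with an estimated range from 800 nM to 30000 nM.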

Compound 3, half-maximal inhibitory concentration: > 10000 nM
Compound 3: no number, only a limit; the forecaster's own chance of this, stated with the estimate: 50%; at least 1.6-fold (0.22 log units) between middle value and limit.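

Going by these compounds alone, compound 3 gives a limit, not a number, so no step from compound 2 to compound 3 can be read. The series stays at one limit: the limit of > 10000 nM in this assay, at which 3 of the 3 values shown sit.

Whether 4-bromophenoxy or 2,4,6-trimethoxyphenyl changes inhibition at all stays open, as the compounds shown give no number.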